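Nitro for methyl on the aryl ring of a dienone

This account rests on a few compounds, and the source may have more. Where it says the series, first, only, none or still open, it means among the compounds named here.

Measured so far:
compound 2 `CC1=C(/C=C/C(=O)/C=C/c2cccc(C)c2)C(C)(C)CCC1O` — 19000 nM
compound 1 `CC1=C(/C=C/C(=O)/C=C/c2cccc(F)c2)C(C)(C)CCC1O` — "not determined" (no result reported)

For the measured compounds named here, compound 2 is the only member of the series with a number in a functional assay on PCa 2b cells (Homo sapiens) for cytotoxicity, read by MTT assay, with a stated time of 72 h; on this read-out lower numbers stand for stronger inhibition and higher numbers for weaker inhibition; for compound 1 this assay gave "not determined" (no result reported), so compound 2 stands alone and cannot be placed against any other entry. In this assay compound 2 gives 19000 nM.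

Compound 3 `CC1=C(/C=C/C(=O)/C=C/c2cccc([N+](=O)[O-])c2)C(C)(C)CCC1O` is the next entry. Its structure differs from compound 2 in one place: nitro in place of methyl on an aromatic carbon. Going by the values given here, no step between measured compounds is available to calibrate this change, so the size of the step in this assay is open.

The expectation for compound 3 is that its value stays near that of compound 2, with the step from a 1.3-fold lower number from compound 2 to compound 3 (0.10 log units; within the scatter) not clearly beyond the scatter. Compound 3 is estimated at 15000 nM, within 5000 nM to 45000 nM.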

Compound 3, half-maximal inhibitory concentration: 6000 nM
Estimate against measurement, compound 3: 2.5-fold (0.40 log units) above; low and high end bracket the measured number.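

In this assay, the aromatic carbon meta to a large group is sensitive to its substituent: nitro in place of methyl gives a 3.2-fold lower number from compound 2 to compound 3 (0.50 log units; beyond the scatter). For the compounds shown here, this is the first step that can be sized, and it shows that a single exchange at this carbon can move the number beyond the scatter, towards stronger inhibition, with the shared core unchanged. Nothing at hand bears on why the number moves.

One step cannot show whether the trend holds across other substituents at this carbon, and compound 1, with fluoro there, gives "not determined" (no result reported), so it adds no second comparison. Also open, on these data alone, are how an amine or a carboxylic acid at this carbon would compare with nitro, and whether nitro at another ring carbon would give a step of similar size.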